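Removing a methoxy group from compound 1: expected cytotoxicity

The source may hold more compounds than are shown below. What is called first, only, known or untested is meant among the compounds shown, and "the series" means these compounds.

Compound 1 `COc1cc(-c2cc(/C=C/C(=O)c3ccc(N)cc3)[nH]n2)cc(OC)c1OC` gives -96%
Compound 2 `COc1ccc(-c2cc(/C=C/C(=O)c3ccc(OC)c(OC)c3)[nH]n2)cc1` gives -97%
Compound 3 `COc1cc(-c2cc(/C=C/C(=O)c3ccc(Cl)c(Cl)c3)[nH]n2)cc(OC)c1OC` gives 48%

In a functional assay on U-251 cells (Homo sapiens) for cytotoxicity, read by sulforhodamine B assay, with a stated time of 48 h, tested at 10 uM (on this read-out higher numbers stand for a weaker effect at the one concentration tested and lower numbers for a stronger effect), compound 1 stands second highest of the three numbers: compound 2 lies within the scatter of it, while compound 3 lies far higher, as the step of a number 144 percentage points higher from compound 1 to compound 3 (beyond the scatter) shows, a change of the aryl on the carbonyl carbon. Compound 4 `COc1ccc(-c2cc(/C=C/C(=O)c3ccc(N)cc3)[nH]n2)cc1OC` differs from compound 1 on the other ring: hydrogen in place of methoxy on an aromatic carbon. Within the data shown here, no measured step touches this ring alone; compound 2, which carries a single methoxy there but also differs on the carbonyl side, sits within the scatter of compound 1. The change is therefore expected to bring no step beyond the scatter, a number 2 percentage points higher from compound 1 to compound 4 (within the scatter). Compound 4 is expected to give -94%, within -100% to -70%.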

Compound 4, a percentage reported as activity, at one concentration (the size of the read-out at that concentration, not a potency): -68%
Compound 4: middle estimate off by 26 percentage points, on the low side; the measured number lies above the stated range.
By their numbers in this assay, from the lowest: compounds 2 and 1 (each within the scatter of the next); then compound 4; then compound 3.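

In this assay, hydrogen in place of methoxy on an aromatic carbon brings a number 28 percentage points higher from compound 1 to compound 4 (beyond the scatter), the first step measured on this ring alone, so this methoxy group's position does bear on the read-out. The closeness of compound 1 and compound 2 could not show this, as compound 2 also differs on the carbonyl side. No available evidence accounts for the step. Going by these compounds, it stays open whether a hydroxy group, a fluorine atom or an ethoxy group at this place would match methoxy. Also open, on these data alone, is whether removing this methoxy has a similar effect with 3,4-dichlorophenyl on the carbonyl carbon.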